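Swapping a fluoro for hydrogen at the assay limit

A few compounds are considered here, and "the series" means these few. Any claim that something is new, unique, unknown or untested is made for them only; others in the source may bear on it.

Values from a functional assay on PC-3 cells (Homo sapiens) for cytotoxicity, read by WST assay, with a stated time of 48 h; a higher number here means a weaker inhibitor, a lower number a stronger inhibitor:
compound 1 `N#C/C(=C\c1c[nH]c2cc(F)ccc12)C(=O)c1c[nH]c2ccccc12`: > 50000 nM
compound 2 `COc1ccc2[nH]cc(/C=C(\C#N)C(=O)c3c[nH]c4cc(F)ccc34)c2c1`: > 50000 nM
compound 3 `N#C/C(=C\c1cn(Cc2ccc(Cl)cc2)c2ccccc12)C(=O)c1c[nH]c2cc(F)ccc12`: > 50000 nM

Compound 3 stands at a limit of the assay, > 50000 nM, and not at a number. The same holds for the other two compounds, so the picture so far is the limit of > 50000 nM in this assay, at which 3 of the 3 values shown sit. Compound 4 `N#C/C(=C\c1cn(Cc2ccc(Cl)cc2)c2ccccc12)C(=O)c1c[nH]c2ccccc12` differs from compound 3 by hydrogen in place of fluoro on an aromatic carbon, turning 6-fluoro-1H-indol-3-yl into 1H-indol-3-yl. Within the data shown here, no measured pair shows this change alone. In this assay no step beyond the scatter is expected, in either direction, given the limit of compound 3 at > 50000 nM. The expected outcome is a number no higher from compound 3 to compound 4 (the limit leaves the size open). Another limit would be no surprise. The estimate for compound 4 is 50000 nM, with an expected range from 15000 nM to 100000 nM.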

Compound 4, half-maximal inhibitory concentration: > 50000 nM
Compound 4: a limit, no number; the forecaster's own chance of this, stated with the estimate: 70%; the middle value lies on the limit itself.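

Compound 3 and compound 4 both sit at a limit of the assay and not at a number, so no step can be read between them. The compounds shown leave open whether fluoro or hydrogen at this place changes cytotoxicity at all.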